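Repositioning one hydroxyl across the shared core

This account rests on a few compounds, and the source may have more. Where it says the series, first, only, none or still open, it means among the compounds named here.

The series is followed in a functional assay on DU-145 cells (Homo sapiens) for cytotoxicity, read by CCK-8 assay, with a stated time of 4 days; on this read-out lower numbers stand for stronger inhibition and higher numbers for weaker inhibition. Compound 1, `Oc1cccc(-c2cc(-c3cccc(O)c3)nc(-c3ccccc3O)c2)c1`, gives in this assay only a limit, > 50000 nM. Compound 2, `Oc1cccc(-c2cc(-c3ccccc3O)cc(-c3cccc(O)c3)n2)c1`, likewise gives only a limit in this assay, > 50000 nM. Both measured values thus sit at the same limit, (the limit of > 50000 nM in this assay, at which 2 of the 2 values shown sit), so compound 2 stands nowhere distinct from compound 1 on the numbers shown, and no step between measured compounds can be read. Compound 3, `Oc1cccc(-c2cc(-c3ccccc3O)cc(-c3ccccc3O)n2)c1`, has not been measured in this assay. The change from compound 2 to compound 3 is 2-hydroxyphenyl in place of 3-hydroxyphenyl on an aromatic carbon, in words 2-hydroxyphenyl in place of 3-hydroxyphenyl on an aromatic carbon. With both measured compounds at the limit, the step from compound 2 to compound 3 is expected to be none beyond the scatter, a number no higher from compound 2 to compound 3 (the limit leaves the size open). Compound 3 is therefore expected to come out near 50000 nM, in the range 20000 nM to 100000 nM, most likely again reported as a limit.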

Compound 3, half-maximal inhibitory concentration: 3980 nM
Estimate against measurement, compound 3: 13-fold (1.10 log units) above; the measured number lies below the stated range.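

For the compounds shown here, on the aromatic carbon next to the ring nitrogen, 2-hydroxyphenyl in place of 3-hydroxyphenyl is the first change to give a measurable number in this assay, with an at least 12-fold lower number from compound 2 to compound 3 (1.09 log units; beyond the scatter). The same change also gives an at least 12-fold lower number from compound 1 to compound 3 (1.09 log units; beyond the scatter), so the read-out responds to where this hydroxyl sits on the phenyl group, which the two earlier compounds could not show. Both steps are lower bounds rather than measured gaps: the limit of > 50000 nM in this assay, at which 2 of the 3 values shown sit.

On these data alone, how a methoxy group or an amine in place of this hydroxyl would read remains open. Going by these compounds alone, also open is whether the same replacement elsewhere on the shared core would give a step of similar size, since compound 3 is the only compound here with a number that is not a limit.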